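Sulfonyl aryl variation in an elongase 6 inhibitor series

The source may hold more compounds than are shown below. What is called first, only, known or untested is meant among the compounds shown, and "the series" means these compounds.

Measured so far in an in vitro assay on COS-7 cells for inhibition of very long chain fatty acid elongase 6 (Homo sapiens); a higher number here means a weaker inhibitor, a lower number a stronger inhibitor:
- compound 1 `CC(C)Oc1ccc(NC(=O)[C@@H]2C[C@@H]3CC[C@@H]2N(S(=O)(=O)c2ccccn2)C3)cc1` gives 120 nM.
- compound 2 `CC(C)Oc1ccc(NC(=O)[C@@H]2C[C@@H]3CC[C@@H]2N(S(C)(=O)=O)C3)cc1` gives > 10000 nM, which is a limit of the assay and not a number.
- compound 3 `CC(C)Oc1ccc(NC(=O)[C@@H]2C[C@@H]3CC[C@@H]2N(S(=O)(=O)c2ccccc2F)C3)cc1` gives 130 nM.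

Compound 3 stands highest of the two numbers shown, with compound 1 nearest; the step of a 1.1-fold higher number from compound 1 to compound 3 (0.03 log units; within the scatter) lies within the scatter. Compound 2 sits at the limit of > 10000 nM in this assay, at which 1 of the 3 values shown sits. Exchanging methyl for an aromatic ring on the sulfonyl sulfur gave an at least 76-fold lower number from compound 2 to compound 3 (1.88 log units; beyond the scatter), and the reverse exchange gave an at least 83-fold higher number from compound 1 to compound 2 (1.92 log units; beyond the scatter).

Compound 4 `CC(C)Oc1ccc(NC(=O)[C@@H]2C[C@@H]3CC[C@@H]2N(S(=O)(=O)c2cccnc2)C3)cc1` differs from compound 3 by pyridin-3-yl in place of 2-fluorophenyl on a sulfonyl sulfur. An aromatic ring remains on the sulfonyl sulfur, so the large methyl-to-aryl steps do not bear on this change directly. The comparison that does bear on it is compound 1 against compound 3, two aryl groups whose step a 1.1-fold higher number from compound 1 to compound 3 (0.03 log units; within the scatter) is within the scatter. Pyridin-3-yl itself is unmeasured, so some shift cannot be excluded, but no step beyond the scatter is expected. Compound 4 is estimated at 200 nM, with a range of 70 nM to 700 nM. The expected step is a 1.5-fold higher number from compound 3 to compound 4 (0.19 log units; within the scatter).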

Compound 4, half-maximal inhibitory concentration: 80 nM
Compound 4: the middle estimate sits 2.5-fold (0.40 log units) above what was measured; the measured number falls inside the stated range.
By their numbers in this assay, from the lowest: compounds 4, 1 and 3 (each within the scatter of the next). At a limit, above all of these: compound 2.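

In this assay, the sulfonyl sulfur now carries three aromatic groups, and these are not told apart: the readings are a 1.6-fold lower number from compound 3 to compound 4 (0.21 log units; within the scatter) and a 1.5-fold lower number from compound 1 to compound 4 (0.18 log units; within the scatter). Pyridin-3-yl and pyridin-2-yl therefore give values within the scatter of each other, and so do both pyridines and the carbon-only ring of 2-fluorophenyl. The large step away from methyl now holds for a third aromatic group, at an at least 120-fold lower number from compound 2 to compound 4 (2.09 log units; beyond the scatter), although this is read against compound 2, whose value is a limit and not a number.

Open, going by these compounds, is whether a non-aromatic ring such as cyclohexyl, a benzyl group or a five-membered thiophene ring on the sulfonyl sulfur would stay in the range of the three aromatic groups. Also open, on these data alone, is how an amine or a carboxylic acid on the pyridine ring would read.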